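The compounds below may be only part of what the source reports. "The series", "measured", "known", "first", "only" and "open" are said of these compounds alone.

Measured in a functional assay on HeLa cells (Homo sapiens) for antiproliferative activity, read by sulforhodamine B assay, with a stated time of 48 h; a lower number here means a stronger inhibitor of growth, a higher number a weaker inhibitor of growth:
compound 1 `CCCCCCc1cn(CCCN2C(=O)COc3ccccc32)nn1` gives 100 nM
compound 2 `O=C1COc2ccccc2N1CCCn1cc(CO)nn1` gives 7300 nM
compound 3 `O=C1COc2ccccc2N1CCCn1cc(CCCCl)nn1` gives 100 nM

Compound 1 and compound 3 share the same number, the lowest of the three, and compound 2 lies far above them. The next compound is compound 4 `O=C1COc2ccccc2N1CCCn1cc(C2(O)CCCCC2)nn1` and has not yet been measured. It carries 1-hydroxycyclohexyl in place of the hexyl of compound 1 on an aromatic carbon of the five-membered aromatic ring with 3 nitrogen. The counted difference is 1-hydroxycyclohexyl in place of hexyl on an aromatic carbon and the shared core stays as it is.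

For the measured compounds named here, two measured steps bear on this change. Hydroxy in place of pentyl gave a 73-fold higher number from compound 1 to compound 2 (1.86 log units; beyond the scatter) and counts as large, so it is the main warning, since compound 4 also brings in a hydroxy group. Chloro in place of propyl gave no change at the digits printed from compound 1 to compound 3 (within the scatter) and so shows that this side chain can change with no shift beyond the scatter. Unlike compound 2, compound 4 keeps a ring of carbon alongside its hydroxy group, and no measured compound combines the two. A move to a higher number is therefore expected, estimated as a 7.0-fold higher number from compound 1 to compound 4 (0.85 log units; beyond the scatter) and smaller than the large step above. Compound 4 is estimated at 700 nM with 150 nM to 4000 nM as the expected range.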

Compound 4, concentration for 50% growth inhibition: 2000 nM
Estimate against measurement, compound 4: 2.9-fold (0.46 log units) below, and the stated range covers the measured number.
By their numbers in this assay, from the lowest: compounds 1 and 3 (each within the scatter of the next); then compound 4; then compound 2.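

In this assay, putting 1-hydroxycyclohexyl on the aromatic carbon of the five-membered aromatic ring with 3 nitrogen gives a 20-fold higher number from compound 1 to compound 4 (1.30 log units; beyond the scatter) when it replaces hexyl and a 20-fold higher number from compound 3 to compound 4 (1.30 log units; beyond the scatter) when it replaces 3-chloropropyl. Its carbon ring therefore does not restore the low numbers of the two compounds without a hydroxy group, although 1-hydroxycyclohexyl in place of hydroxymethyl gives a 3.7-fold lower number from compound 2 to compound 4 (0.56 log units; beyond the scatter), so compound 4 still sits below compound 2. Across these four compounds, the two with a hydroxy group have the two highest numbers, and none goes against this, but no measured evidence here accounts for the pattern.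

The compounds shown leave open whether the rise from compound 1 to compound 4 goes with the hydroxy group, the carbon ring or the two together, and a plain cyclohexyl group at this position would separate these readings. Also open, going by these compounds, is how this position responds to an amine or a carboxylic acid, or to a longer chain ending in a hydroxy group.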